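Extending the chain on the sulfur-bound carbon

The source may hold more compounds than are shown below. What is called first, only, known or untested is meant among the compounds shown, and "the series" means these compounds.

Measured so far in a functional assay on HT cells (Homo sapiens) for antiproliferative activity, read by fluorescence, with a stated time of 72 h; on this read-out lower numbers stand for stronger inhibition of growth and higher numbers for weaker inhibition of growth:
Compound 1 `CC(C)c1n[nH]c2c(NCc3ccc(-c4ccccn4)cc3)nc(SCCNC(=N)N)nc12` gives 390 nM.
Compound 2 `CSc1nc(NCc2ccc(-c3ccccn3)cc2)c2[nH]nc(C(C)C)c2n1` gives 783 nM.
Compound 3 `CC(C)c1n[nH]c2c(NCc3ccc(-c4ccccn4)cc3)nc(SCCn3ccnc3)nc12` gives 155 nM.

Compound 2 shows the highest of the three numbers, though its gap to compound 1 is within the scatter, while compound 3 sits clearly lower. Compound 4 `CC(C)c1n[nH]c2c(NCc3ccc(-c4ccccn4)cc3)nc(SCC(C)(C)O)nc12` differs from compound 2 by 1-hydroxy-1-methylethyl in place of hydrogen on a saturated chain carbon bound to a sulfur. For the measured compounds named here, two measured steps touch the same carbon: a 5.1-fold lower number from compound 2 to compound 3 (0.70 log units; beyond the scatter), and in the reverse direction a 2.0-fold higher number from compound 1 to compound 2 (0.30 log units; within the scatter). In both, attaching a group at this carbon goes with a lower number, modestly in one case and within the scatter in the other. A modest lowering is therefore expected for compound 4, about a 2.2-fold lower number from compound 2 to compound 4 (0.35 log units; beyond the scatter). Compound 4 is estimated at 350 nM, with a range from 150 nM to 800 nM.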

Compound 4, concentration for 50% growth inhibition: 507 nM
Estimate against measurement, compound 4: 1.4-fold (0.16 log units) below; the range from low to high includes it.
By their numbers in this assay, from the lowest: compound 3; then compounds 1, 4 and 2 (each within the scatter of the next).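

Putting 1-hydroxy-1-methylethyl on this carbon leaves the number within the scatter of the hydrogen compound (a 1.5-fold lower number from compound 2 to compound 4 (0.19 log units; within the scatter)). The same holds when it replaces the group carried by compound 1 (a 1.3-fold higher number from compound 1 to compound 4 (0.11 log units; within the scatter)). Replacing (1H-imidazol-1-yl)methyl with it is a clearer step (a 3.3-fold higher number from compound 3 to compound 4 (0.51 log units; beyond the scatter)), so attaching a group here does not by itself guarantee a clearly lower number, and among these compounds the imidazole-bearing compound 3 alone stands apart from all the others.

From the compounds shown here alone, whether a simple amine, a carboxylic acid or a longer chain at this carbon would match compound 3 remains open. Nothing measured here explains the difference between these groups.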